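Pyridin-4-yl in place of pyridin-3-yl: cytotoxicity notes

A few compounds are considered here, and "the series" means these few. Any claim that something is new, unique, unknown or untested is made for them only; others in the source may bear on it.

- compound 1 `COc1ccc([C@H]2CC(=O)N(c3cccc(C(F)(F)F)c3)C2)cc1OC1CCCC1` in a functional assay on HEK293 cells (Homo sapiens) for cytotoxicity (a higher number here means that more compound is tolerated, a lower number that less compound is tolerated), gives > 10000 nM as a limit
- compound 2 `COc1ccc([C@H]2CC(=O)N(c3cccnc3)C2)cc1OC1CCCC1` in this assay gives > 10000 nM as a limit

Compound 2 gives > 10000 nM as a limit, not a number. Compound 3 `COc1ccc([C@H]2CC(=O)N(c3ccncc3)C2)cc1OC1CCCC1` differs from compound 2 by pyridin-4-yl in place of pyridin-3-yl on an amide-type nitrogen in a ring with pyridin-4-yl in place of pyridin-3-yl on an amide-type nitrogen in a ring. Among the measured compounds shown here, the one measured step at that nitrogen is a step that the two limits leave unreadable from compound 1 to compound 2 and it offers no size. For the measured compounds named here, the series so far shows only the limit of > 10000 nM in this assay, at which 2 of the 2 values shown sit, and no number. No step beyond the scatter is therefore expected in this assay and another limit is the likely report. The expected step is a step that the limit leaves unreadable from compound 2 to compound 3 as estimated here. Compound 3 is estimated at 15000 nM with an expected range of 6000 nM to 40000 nM in this assay.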

Compound 3, half-maximal cytotoxic concentration: > 10000 nM
Compound 3 was reported as a limit; the forecaster's own chance of this, stated with the estimate: 85%; the middle value is on the limit's open side.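

In this assay, among the compounds shown here, compound 3 gives > 10000 nM as a limit, not a number, so no step among compound 1, compound 2 and compound 3 can be read. The concentration at which any of them becomes cytotoxic stays open: the limit of > 10000 nM in this assay, at which 3 of the 3 values shown sit.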